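Benzylamino Replacing Fluorophenylamino on the Shared Amide Core

The source may hold more compounds than are shown below. What is called first, only, known or untested is meant among the compounds shown, and "the series" means these compounds.

Compound 1 `CCCOc1ccc(C(=O)Nc2cccc(C)n2)cc1` and compound 2 `CCCOc1ccc(C(=O)Nc2cccc(Nc3cccc(F)c3)n2)cc1` share one amide-linked core. In an in vitro assay on HEK-tsA201 cells for antagonist activity at Neuronal acetylcholine receptor; alpha4/beta2 (Homo sapiens), read by fluorescence and calcium flux (on this read-out lower numbers stand for stronger inhibition and higher numbers for weaker inhibition), compound 1 gives 7500 nM. For compound 2 only a limit of the assay is recorded, > 100000 nM. The step of an at least 13-fold higher number from compound 1 to compound 2 (1.12 log units; beyond the scatter) is large, so compound 2 stands at the weak end of the two values shown, sitting at the limit of > 100000 nM in this assay, at which 1 of the 2 values shown sits.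

Compound 3 `CCCOc1ccc(C(=O)Nc2cccc(NCc3ccccc3)n2)cc1` has not been measured in this assay. It differs from compound 2 by benzyl in place of 3-fluorophenyl on a nitrogen on an aromatic ring; cut one bond further out, the change reads (3-fluorophenyl)amino to benzylamino. Among the measured compounds shown here, the only measured step that bears on it is an at least 13-fold higher number from compound 1 to compound 2 (1.12 log units; beyond the scatter), which moved from a methyl on an aromatic carbon to the (3-fluorophenyl)amino group. No measured pair exchanges one substituent on that nitrogen for another, so neither a gain nor a further loss can be read from what is shown. Compound 3 is therefore expected to remain near the limit, with the step of a number no higher from compound 2 to compound 3 (the limit leaves the size open) expected to stay within the scatter. For compound 3 the estimated value in this assay is 100000 nM, between 30000 nM and 300000 nM, most likely again reported only as a limit.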

Compound 3, half-maximal inhibitory concentration: > 100000 nM
Compound 3 ended at the assay's limit; the forecaster's own chance of this, stated with the estimate: 70%; the middle value sits exactly at the limit.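

Benzylamino in place of the methyl on an aromatic carbon gives an at least 13-fold higher number from compound 1 to compound 3 (1.12 log units; beyond the scatter) in this assay and so repeats what (3-fluorophenyl)amino did at this place. Compound 2 and compound 3 are both recorded only as limits of the assay, so the step between them cannot be read, and the exchange of 3-fluorophenyl for benzyl on the nitrogen cannot be ranked in either direction. What the result adds is that the loss is no longer seen with a single substituent: it appears with both 3-fluorophenyl and benzyl on that nitrogen, which has no fluorine in the second case, and of the three compounds only compound 1, with its methyl, gives a value that is not a limit: the limit of > 100000 nM in this assay, at which 2 of the 3 values shown sit.

Going by these compounds, whether a plain amino group or an ethylamino group at this place would also sit at the limit stays open, and with it how much of the substituent on the nitrogen is needed for the loss. Also open, on these data alone, is whether a methoxy group or a chlorine in place of the methyl would give a readable value.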